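This account rests on a few compounds, and the source may have more. Where it says the series, first, only, none or still open, it means among the compounds named here.

Working notes on the series. Among the measured compounds shown here, compound 1 `O=c1[nH]c2ccccc2cc1-c1nc2cc(F)ccc2[nH]1` is the only member with a number of its own in a functional assay on HepG2 cells (Homo sapiens) for cytotoxicity, read by MTT assay, with a stated time of 48 h (a higher number here means a weaker inhibitor, a lower number a stronger inhibitor), where compound 1 gives 15200 nM. Compound 2 `Cc1ccc2[nH]c(=O)c(-c3nc4cc(F)ccc4[nH]3)cc2c1` carries a methyl in place of hydrogen on an aromatic carbon. In this assay compound 2 reaches only a limit of the assay, > 100000 nM, and no number. For the measured compounds named here, the single measured step, an at least 6.5-fold higher number from compound 1 to compound 2 (0.81 log units; beyond the scatter), is all the series shows so far, and its size rests on (the limit of > 100000 nM in this assay, at which 1 of the 2 values shown sits). Compound 3 `O=c1[nH]c2ccccc2cc1-c1nc2cc(Cl)ccc2[nH]1` differs from compound 1 by chloro in place of fluoro on an aromatic carbon. Going by the values given here, no measured step touches this exchange of one halogen for another: the step from compound 1 to compound 2 concerns a methyl and says nothing about the fluoro. With the shared core kept and the change confined to a single heavy atom, no step beyond the scatter is expected in this assay from compound 1 to compound 3, in either direction. Compound 3 is therefore expected to give 12000 nM in this assay, within a range from 4000 nM to 40000 nM, which means an expected step of a 1.3-fold lower number from compound 1 to compound 3 (0.10 log units; within the scatter).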

Compound 3, half-maximal inhibitory concentration: 8450 nM
Compound 3: middle estimate off by 1.4-fold (0.15 log units), on the high side, within the range that was stated.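

Chloro in place of fluoro on this aromatic carbon gives a 1.8-fold lower number from compound 1 to compound 3 (0.25 log units; within the scatter) in this assay and so shows that, for this one pair, the exchange of one halogen for the other does not move the number beyond the scatter. Among the compounds shown here, the earlier step, an at least 6.5-fold higher number from compound 1 to compound 2 (0.81 log units; beyond the scatter), concerned a methyl and gave no reading on the halogen position, so this pair is the first direct information on that carbon of the shared core, though it covers only fluoro and chloro. Nothing measured here accounts for the size of this step, and no property of either halogen can be drawn from the data at hand.

From the compounds shown here alone, whether a bromo, a methoxy, an amine or a carboxylic acid on this aromatic carbon would also stay within the scatter of compound 1 remains open, so the tolerance seen here cannot yet be extended beyond the two halogens. Also open, going by these compounds, is whether the methyl of compound 2 and the chloro of compound 3, brought together on the shared core, would give a number set by the methyl, by the chloro or by both.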